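Oxolane for cyclopentyl on the amide of compound 2

The source may hold more compounds than are shown below. What is called first, only, known or untested is meant among the compounds shown, and "the series" means these compounds.

For the measured compounds named here, compound 2 `Cc1cc(NC(=O)C2CCCC2)nn1Cc1cc(Cl)ccc1OCc1ccccc1` holds the lowest number so far in an assay on CHO-K1 cells for displacement of a labelled ligand from prostaglandin E2 receptor EP1 subtype (Homo sapiens); a higher number here means a weaker inhibitor, a lower number a stronger inhibitor: compound 2 gives 15.9 nM. Its nearest neighbour is compound 1 `Cc1cc(C(=O)Nc2ccccn2)nn1Cc1cc(Cl)ccc1OCc1ccccc1`, which in this assay gives 126 nM; the measured step of a 7.9-fold lower number from compound 1 to compound 2 (0.90 log units; beyond the scatter) is the only one available and concerns a different site, the whole amide being reversed and its ring exchanged. Compound 3 `Cc1cc(NC(=O)C2CCOC2)nn1Cc1cc(Cl)ccc1OCc1ccccc1` carries the change (oxolan-3-yl in place of cyclopentyl on a carbonyl carbon). Going by the values given here, no measured pair touches the ring on that carbonyl carbon, so the step from compound 2 to compound 3 has no close precedent; the step from compound 1 to compound 2 only shows that this assay answers to changes around the amide. A small-to-modest rise in the number is expected for compound 3, the step being estimated as a 2.5-fold higher number from compound 2 to compound 3 (0.40 log units; beyond the scatter). Compound 3 is therefore estimated at 40 nM, with a range from 12 nM to 130 nM.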

Compound 3, half-maximal inhibitory concentration: 39.8 nM
Compound 3: the middle estimate sits 1.0-fold (0.00 log units) above what was measured; measured number inside the range.
By their numbers in this assay, from the lowest: compound 2; then compound 3; then compound 1.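

In this assay, the ring on the carbonyl carbon now has a measured step of its own: oxolan-3-yl in place of cyclopentyl gives a 2.5-fold higher number from compound 2 to compound 3 (0.40 log units; beyond the scatter), a change that brings in 1 hydrogen-bond acceptor while keeping a five-membered non-aromatic ring. The ring oxygen therefore costs part of the advantage of this amide series over compound 1 but does not remove it, as a 3.2-fold lower number from compound 1 to compound 3 (0.50 log units; beyond the scatter) still lies beyond the scatter. Nothing on hand accounts for the rise in the number on going to oxolan-3-yl.

A single pair cannot separate the effect of having a ring oxygen from that of where it sits, a question that oxolan-2-yl would address. As far as these compounds go, whether larger rings are accepted on this carbonyl carbon remains open, as does the response to a ring amine, for which cyclohexyl and piperidin-4-yl would be informative.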